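The source may report more compounds than this note shows. Statements on the series, on what has been measured and on what is new or still open speak of the compounds shown alone.

Compound 2 `CC1=CC[C@H](C(C)(C)NC(=S)N/N=C/c2ccc(O)cc2)CC1` stands at the far end of what has been measured: in a functional assay on 786-0 cells (Homo sapiens) for inhibition, read by sulforhodamine B assay, with a stated time of 48 h (on this read-out lower numbers stand for stronger inhibition of growth and higher numbers for weaker inhibition of growth), compound 2 reaches only a limit, > 100000 nM. Compound 1 `COc1ccc(/C=N/NC(=S)NC(C)(C)[C@H]2CC=C(C)CC2)cc1` gives 29600 nM in this assay. Compound 3 `CC1=CC[C@H](C(C)(C)NC(=S)N/N=C/c2ccc(N(C)C)cc2)CC1` also reaches a limit, > 100000 nM. Compound 4 `CC1=CC[C@H](C(C)(C)NC(=S)N/N=C/c2ccco2)CC1` differs from compound 2 by furan-2-yl in place of 4-hydroxyphenyl on a carbon with a double bond to nitrogen. Within the data shown here, no measured step exchanges the six-membered ring for a five-membered one, so the closest guides are an at least 3.3-fold higher number from compound 1 to compound 2 (0.52 log units; beyond the scatter) and an at least 3.3-fold higher number from compound 1 to compound 3 (0.52 log units; beyond the scatter), each moving away from the methoxy compound toward weaker growth inhibition. Because compound 2 sits at the limit of > 100000 nM in this assay, at which 2 of the 3 values shown sit, the size of its step to compound 4 cannot be read exactly. Compound 4 is expected near 60000 nM, between 20000 nM and 150000 nM, an expected step of an at least 1.6-fold lower number from compound 2 to compound 4 (0.22 log units; that floor lies within the scatter).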

Compound 4, concentration for total growth inhibition: 9800 nM
Compound 4: middle estimate off by 6.1-fold (0.79 log units), on the high side; measured number outside the range, below it.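

Among these compounds, replacing 4-methoxyphenyl with furan-2-yl is the first change at this place to strengthen growth inhibition, giving a 3.0-fold lower number from compound 1 to compound 4 (0.48 log units; beyond the scatter) in this assay, so a six-membered aromatic ring of carbon only is not required here. Replacing 4-hydroxyphenyl with furan-2-yl gives an at least 10-fold lower number from compound 2 to compound 4 (1.00 log units; beyond the scatter). That step is only a floor because compound 2 sits at a limit: the limit of > 100000 nM in this assay, at which 2 of the 4 values shown sit.

The compounds shown leave open whether the oxygen of furan-2-yl matters, which a thiophene ring would test. Going by these compounds, how a pyridine ring or a simple alkyl chain would read at this place also remains open.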